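Pyrazinyl replacing pyrazolyl on the amide nitrogen

The compounds below may be only part of what the source reports. "The series", "measured", "known", "first", "only" and "open" are said of these compounds alone.

Measured compounds:
compound 1 `Cc1ccc(OCC(=O)N(Cc2cccs2)C(C)(C)C)cc1`, 11000 nM
compound 2 `C=CCN(Cc1cccs1)C(=O)COc1ccc(C)cc1`, 20 nM
compound 3 `Cc1ccc(OCC(=O)N(Cc2cccs2)c2c[nH]nc2C)cc1`, 0.4 nM

In an assay on HEK293 cells for agonist activity at transient receptor potential cation channel subfamily M member 8 (Homo sapiens), read by fluorescence and calcium flux, with a stated time of 15 min (on this read-out lower numbers stand for an effect already at smaller amounts and higher numbers for an effect only at larger amounts of compound), compound 3 gives the lowest number of the three; compound 2 lies a 50-fold lower number from compound 2 to compound 3 (1.70 log units; beyond the scatter) away and compound 1 a 28000-fold lower number from compound 1 to compound 3 (4.44 log units; beyond the scatter) away. Compound 4 `Cc1ccc(OCC(=O)N(Cc2cccs2)c2cnccn2)cc1` carries the change (pyrazin-2-yl in place of 3-methyl-1H-pyrazol-4-yl on an amide-type nitrogen). Within the data shown here, no measured step swaps one aromatic group for another at this nitrogen; the steps that bear on it, a 550-fold lower number from compound 1 to compound 2 (2.74 log units; beyond the scatter) and a 28000-fold lower number from compound 1 to compound 3 (4.44 log units; beyond the scatter), show that what stands on this nitrogen moves the number strongly. Since compound 4 keeps an aromatic group there, its number is expected to stay well under that of compound 1 but likely above that of compound 3, an estimated step of a 20-fold higher number from compound 3 to compound 4 (1.30 log units; beyond the scatter). Compound 4 is therefore expected at 8 nM, within 1 nM to 60 nM.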

Compound 4, half-maximal effective concentration: 1240 nM
The estimate for compound 4 lay 160-fold (2.19 log units) below the measured number, and the stated range ends below it.
By their numbers in this assay, from the lowest: compound 3; then compound 2; then compound 4; then compound 1.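

In this assay, an aromatic group on the amide-type nitrogen does not by itself keep the number low: pyrazin-2-yl in place of 3-methyl-1H-pyrazol-4-yl, with equal heavy-atom counts, gives a large rise (a 3100-fold higher number from compound 3 to compound 4 (3.49 log units; beyond the scatter)). Pyrazin-2-yl also trails the non-aromatic allyl (a 62-fold higher number from compound 2 to compound 4 (1.79 log units; beyond the scatter)) and retains only a modest gain over tert-butyl (an 8.9-fold lower number from compound 1 to compound 4 (0.95 log units; beyond the scatter)). No measurement accounts for this rise.

On these data alone, the change alters ring size, hydrogen-bond donor count and the methyl together, so which of these matters stays open. As far as these compounds go, how an unsubstituted 1H-pyrazol-4-yl or a pyridin-3-yl on this nitrogen would read also remains open.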